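Aryl swap on the shared core, calcium flux read-out

The compounds below may be only part of what the source reports. "The series", "measured", "known", "first", "only" and "open" are said of these compounds alone.

In an assay on HL-60 cells for agonist activity at N-formyl peptide receptor 3 (Homo sapiens), read by calcium flux (on this read-out lower numbers stand for an effect already at smaller amounts and higher numbers for an effect only at larger amounts of compound), compound 1 `COc1cccc(Cc2cc(-c3ccccc3)nn(CC(=O)Nc3ccc(F)cc3)c2=O)c1` gives only the assay limit, > 50000 nM. Compound 2 `COc1cccc(Cc2cc(-c3cccs3)nn(CC(=O)Nc3ccc(F)cc3)c2=O)c1` likewise gives only the limit > 50000 nM in this assay. The step that the two limits leave unreadable from compound 1 to compound 2 is therefore unreadable, and the limit of > 50000 nM in this assay, at which 2 of the 2 values shown sit, shows both values sitting at that limit. Compound 3 `COc1ccc(-c2cc(Cc3cccc(OC)c3)c(=O)n(CC(=O)Nc3ccc(F)cc3)n2)cc1` carries 4-methoxyphenyl in place of thiophen-2-yl on an aromatic carbon. No readable measured step bears on this change, and compound 2 stands at the limit with no number. The expected step is a step that the limit leaves unreadable from compound 2 to compound 3, not readable against a limit. The estimate for compound 3 in this assay is 60000 nM, within 15000 nM to 250000 nM.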

Compound 3, half-maximal effective concentration: > 50000 nM
Compound 3 was reported as a limit; the forecaster's own chance of this, stated with the estimate: 80%; the middle value is on the limit's open side.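

Compound 3 also sits at the assay limit, so no step among compound 1, compound 2 and compound 3 can be read: the limit of > 50000 nM in this assay, at which 3 of the 3 values shown sit.

From the compounds shown here alone, how phenyl, thiophen-2-yl and 4-methoxyphenyl on the shared core rank in this assay stays open.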